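The compounds below may be only part of what the source reports. "The series", "measured", "known", "first", "only" and "open" are said of these compounds alone.

In a functional assay on KYSE-450 cells (Homo sapiens) for inhibition, read by CCK-8 assay, with a stated time of 48 h (on this read-out higher numbers stand for weaker inhibition and lower numbers for stronger inhibition), three compounds sharing one core have been tested so far. Compound 1 `COc1cc(N(Cc2ccc(C)cc2)C(=O)CSC(=S)N2CCN(C(=O)OC(C)(C)C)CC2)cc(OC)c1OC` reads > 20000 nM, which is a limit of the assay and not a number. Compound 2 `COc1ccc(CN(C(=O)CSC(=S)N2CCN(C(=O)OC(C)(C)C)CC2)c2cc(OC)c(OC)c(OC)c2)cc1OC` reads > 20000 nM, again a limit of the assay. Among the compounds with values here, compound 3 `COc1ccc(CN(C(=O)CSC(=S)N2CCN(C(=O)OC(C)(C)C)CC2)c2cc(OC)c(OC)c(OC)c2)cc1Br` gives 1850 nM, the only true number in the set.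

Compound 4 `COc1ccc(CN(C(=O)CSC(=S)N2CCN(C(=O)OC(C)(C)C)CC2)c2cc(OC)c(OC)c(OC)c2)cc1N=[N+]=[N-]` keeps all of compound 3 except one group: azido in place of bromo on an aromatic carbon, ortho to a methoxy group (azido in place of bromo on an aromatic carbon).

Within the data shown here, two measured steps bear on this change. The closest is an at least 10-fold lower number from compound 2 to compound 3 (1.03 log units; beyond the scatter), where bromo takes the place of methoxy on that same carbon. The other is an at least 10-fold lower number from compound 1 to compound 3 (1.03 log units; beyond the scatter), which exchanges the whole 4-methylphenyl for 3-bromo-4-methoxyphenyl. Both are large, so the group on this ring can matter greatly in this assay. Neither step shows how azido compares with bromo, so compound 3 at 1850 nM is the best anchor for an expectation. The estimated step is a 1.4-fold higher number from compound 3 to compound 4 (0.13 log units; within the scatter), and no shift beyond the scatter is expected. For compound 4 the estimate is 2500 nM, with an expected range of 600 nM to 12000 nM.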

Compound 4, half-maximal inhibitory concentration: 840 nM
For compound 4 the middle estimate is 3.0-fold (0.47 log units) above the measured one, within the range that was stated.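

In this assay, within the data shown here, bromo is not the only group at this position that gives a measurable reading, and azido, which holds no halogen, goes further, with a 2.2-fold lower number from compound 3 to compound 4 (0.34 log units; beyond the scatter); this step is modest but beyond the scatter. Set against the methoxy group on the same carbon, azido gives an at least 23-fold lower number from compound 2 to compound 4 (1.37 log units; beyond the scatter), and exchanging the whole 4-methylphenyl for 3-azido-4-methoxyphenyl gives an at least 23-fold lower number from compound 1 to compound 4 (1.37 log units; beyond the scatter). These two large steps give only a minimum size, not an exact one, because each starts from a compound that reads at a limit of the assay and not at a number: the limit of > 20000 nM in this assay, at which 2 of the 4 values shown sit.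

As far as these compounds go, with only methoxy, bromo and azido seen on this carbon, it remains open how a plain hydrogen, an amine, a nitrile or a carboxylic acid would read there. From the compounds shown here alone, it is also open whether azido would give the same step without the methoxy group that it sits ortho to, since every compound here carrying azido or bromo also carries that methoxy group.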